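A few compounds are considered here, and "the series" means these few. Any claim that something is new, unique, unknown or untested is made for them only; others in the source may bear on it.

Of the compounds shown here, three have so far been measured in a physicochemical assay for acid dissociation, and a fourth is waiting for its number. Compound 1 `Clc1ccc(Oc2ccc3c(NCCCNCc4ccco4)ccnc3c2)cc1` gives 9.28. Compound 2 `c1coc(CNCCCNc2ccnc3cc(-c4cccc5ccccc45)ccc23)c1` gives 9.47. Compound 3 `COc1cccc(CNCCCNc2ccnc3cc(-c4cccc5ccccc45)ccc23)c1O` gives 9.47, which puts compound 3 and compound 2 together at the top of the three numbers, with no separation between them.

Compound 2 and compound 3 share one core and differ only in the group hanging off the chain: 2-hydroxy-3-methoxyphenyl in place of furan-2-yl on a saturated chain carbon bound to an amine nitrogen. That swap produced no change at the digits printed from compound 2 to compound 3 (within the scatter). Compound 2 and compound 1 differ instead at the core itself: 4-chlorophenoxy in place of naphthalen-1-yl on an aromatic carbon. That swap produced a number 0.19 log units lower from compound 2 to compound 1 (within the scatter), a shift too small to be told apart from the scatter of the method.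

The unmeasured compound 4 `COc1cccc(CNCCCNc2ccnc3cc(Oc4ccc(Cl)cc4)ccc23)c1O` stands to compound 3 exactly as compound 1 stands to compound 2: 4-chlorophenoxy in place of naphthalen-1-yl on an aromatic carbon. The place of the change is described in the same words for both pairs, so this is the same change made a second time, on the core carrying the 2-hydroxy-3-methoxybenzyl group rather than the (furan-2-yl)methyl group. Because that change gave a number 0.19 log units lower from compound 2 to compound 1 (within the scatter) once, and because the chain group itself gave no change at the digits printed from compound 2 to compound 3 (within the scatter), a repeat of roughly the same small shift is the natural expectation. The step from compound 3 to compound 4 is therefore estimated at a number 0.19 log units lower from compound 3 to compound 4 (within the scatter). Compound 4 is expected to give about 9.28, most likely somewhere between 9 and 9.56.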

Compound 4, acid dissociation constant: 9.28
Compound 4: middle estimate and measured number agree at the digits printed; measured number inside the range.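

In this assay, putting 4-chlorophenoxy in place of naphthalen-1-yl on the core bearing the 2-hydroxy-3-methoxyphenyl group gave a number 0.19 log units lower from compound 3 to compound 4 (within the scatter), and the same swap on the core bearing the furan-2-yl group gave a number 0.19 log units lower from compound 2 to compound 1 (within the scatter), so the step reads the same on both, and the change at the other place reads no change at the digits printed from compound 1 to compound 4 (within the scatter), just as it does with naphthalen-1-yl in no change at the digits printed from compound 2 to compound 3 (within the scatter). Within these four compounds, then, the two changes simply add up, and nothing in the square goes against that. It does not show that this swap has a real, reproducible effect, however, since each step lies within the scatter of the method, and agreement between two steps this small is weak support for carrying the change to another core.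

No measurement shown here explains why the numbers fall as they do. From the compounds shown here alone, it remains open whether the swap would read the same on a core with a carboxylic acid in place of the furan-2-yl group, or with a longer chain in place of the present one.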